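This account rests on a few compounds, and the source may have more. Where it says the series, first, only, none or still open, it means among the compounds named here.

The measured compounds and their values in an assay on HEK293 cells for displacement of a labelled ligand from D(4) dopamine receptor (Homo sapiens), read by scintillation counting, with a stated time of 60 min; a higher number here means a weaker inhibitor, a lower number a stronger inhibitor:

compound 1 `Cc1cccc(NC(=O)CN2CCN(c3ccc(Cl)cn3)CC2)c1` gives 95 nM
compound 2 `Cc1cccc(NC(=O)CN2CCN(c3ncccn3)CC2)c1` gives 318 nM

Compound 2 stands with the highest of the two numbers in this assay; its nearest neighbour is compound 1, and the step of a 3.3-fold higher number from compound 1 to compound 2 (0.52 log units; beyond the scatter) lies beyond the scatter. Compound 3 `Cc1cccc(NC(=O)CN2CCN(c3ccccn3)CC2)c1` has not yet been measured in this assay. It differs from compound 2 in one place: pyridin-2-yl in place of pyrimidin-2-yl on an amine nitrogen in a ring.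

Among the compounds with values here, only one measured step bears on this change. In it, a 3.3-fold higher number from compound 1 to compound 2 (0.52 log units; beyond the scatter) accompanies the move from 5-chloropyridin-2-yl to pyrimidin-2-yl. Compound 3 carries pyridin-2-yl, which shares the pyridine ring with compound 1 but lacks the chlorine; how much of that step rests on the chlorine and how much on the second ring nitrogen cannot be separated from these two compounds. Part of the difference is therefore expected to be recovered, and a modest lowering of the number in this assay is expected, of about a 1.7-fold lower number from compound 2 to compound 3 (0.22 log units; within the scatter), possibly no more than the scatter. For compound 3 the expected value in this assay is 190 nM, within a range of 80 nM to 450 nM.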

Compound 3, inhibition constant: 212 nM
The estimate for compound 3 lay 1.1-fold (0.05 log units) below the measured number; measured number inside the range.
By their numbers in this assay, from the lowest: compound 1; then compounds 3 and 2 (each within the scatter of the next).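

In this assay the ring change can now be read on its own: pyridin-2-yl in place of pyrimidin-2-yl on the amine nitrogen in the ring gives a 1.5-fold lower number from compound 2 to compound 3 (0.18 log units; within the scatter) and so does not separate the two compounds beyond the usual spread of repeated measurements. Within the data shown here, the chloro can also be read alone for the first time, as hydrogen in its place on the aromatic carbon gives a 2.2-fold higher number from compound 1 to compound 3 (0.35 log units; beyond the scatter) and this modest step stands clear of that spread. The earlier step, a 3.3-fold higher number from compound 1 to compound 2 (0.52 log units; beyond the scatter) as it stood, had joined both changes, and of the two only the loss of the chloro now gives a step beyond the scatter when taken singly.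

From the compounds shown here alone, whether this holds only for chloro on the pyridin-2-yl ring remains open, since bromo, methyl, methoxy or nitrile at that aromatic carbon, or a chloro on the pyrimidin-2-yl ring, would be needed to show how far it extends. No measurement offered here explains any of these steps.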